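Amide nitrogen substituents on the shared core

A few compounds are considered here, and "the series" means these few. Any claim that something is new, unique, unknown or untested is made for them only; others in the source may bear on it.

The three measured compounds share one core and differ only in the group on an amide-type nitrogen. Compound 1 `CCC1C(=O)N(C)c2cnc(-n3ccc4cc(C(=O)NC)ccc43)nc2N1c1ccn(C)n1` gives 13200 nM in a functional assay on Huh-7 cells (Homo sapiens) for antiproliferative activity, read by CCK-8 assay, with a stated time of 72 h; on this read-out lower numbers stand for stronger inhibition of growth and higher numbers for weaker inhibition of growth. Compound 2 `CCC1C(=O)N(C)c2cnc(-n3ccc4cc(C(=O)NC(C)C)ccc43)nc2N1c1ccn(C)n1` gives 6740 nM in this assay, and compound 3 `CCCCNC(=O)c1ccc2c(ccn2-c2ncc3c(n2)N(c2ccn(C)n2)C(CC)C(=O)N3C)c1` gives 8670 nM in this assay. As the numbers read, compound 3 stands second highest of the three, nearest to compound 2 and furthest from compound 1, yet both gaps sit within the scatter. The measured steps are a 2.0-fold lower number from compound 1 to compound 2 (0.29 log units; within the scatter), a 1.5-fold lower number from compound 1 to compound 3 (0.18 log units; within the scatter) and a 1.3-fold higher number from compound 2 to compound 3 (0.11 log units; within the scatter), none of them beyond the scatter.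

Compound 4 `CCC1C(=O)N(C)c2cnc(-n3ccc4cc(C(=O)NC5CCCC5)ccc43)nc2N1c1ccn(C)n1` is not yet measured. It differs from compound 3 by cyclopentyl in place of butyl on an amide-type nitrogen. For the measured compounds named here, the steps that bear on this change are the two that also exchange the group on the amide-type nitrogen, a 2.0-fold lower number from compound 1 to compound 2 (0.29 log units; within the scatter) and a 1.3-fold higher number from compound 2 to compound 3 (0.11 log units; within the scatter), both within the scatter. A non-aromatic ring of carbon only in place of a chain is a change of the same kind, so no step beyond the scatter is expected in this assay. Compound 4 is therefore estimated at 7000 nM, within a range of 3000 nM to 16000 nM, meaning an expected step of a 1.2-fold lower number from compound 3 to compound 4 (0.09 log units; within the scatter).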

Compound 4, concentration for 50% growth inhibition: "not active" (no number reported)
Compound 4 has no reported number here, and the estimate cannot be compared.
By their numbers in this assay, from the lowest: compounds 2, 3 and 1 (each within the scatter of the next).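

For the compounds shown here, compound 4 is recorded as "not active" in this assay with no number, so no step from compound 3 or any other compound to compound 4 can be read. The compounds shown leave open how cyclopentyl compares numerically with butyl, isopropyl or methyl on the amide-type nitrogen. No evidence on this result is available.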